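A few compounds are considered here, and "the series" means these few. Any claim that something is new, unique, unknown or untested is made for them only; others in the source may bear on it.

Working notes on the series. Of the compounds shown here, three with a shared core have been measured: compound 1 `Nc1ccccc1NC(=O)c1ccc(CSC(=S)N2CCN(C(c3ccccc3)c3ccccc3)CC2)cc1`, compound 2 `N#Cc1ccc(N2CCN(C(=S)SCc3ccc(C(=O)Nc4ccccc4N)cc3)CC2)cc1` and compound 3 `CN1CCN(C(=S)SCc2ccc(C(=O)Nc3ccccc3N)cc2)CC1`. In a functional assay on MGC-803 cells (Homo sapiens) for antiproliferative activity, read by CCK-8 assay, with a stated time of 72 h, tested at 8 uM (a higher number here means a stronger effect of the compound at the concentration tested, a lower number a weaker effect), compound 1 gives 9.9%, compound 2 gives 37.6% and compound 3 gives 84.4%, the highest of the three, with both other values beyond the scatter below it. For the measured compounds named here, the only single-place step measured, a number 46.8 percentage points higher from compound 2 to compound 3 (beyond the scatter), shows the smaller group on the amine nitrogen in the ring going with the far larger read-out; compound 1, carrying a larger group still, sits lowest. Compound 4 `Nc1ccccc1NC(=O)c1ccc(CSC(=S)N2CCN(Cc3ccccc3)CC2)cc1` differs from compound 3 by phenyl in place of hydrogen on a saturated chain carbon bound to an amine nitrogen in a ring. Enlarging this group again is expected to lower this assay, by about a number 34.4 percentage points lower from compound 3 to compound 4 (beyond the scatter). Compound 4 is therefore estimated at 50%, within 25% to 75%.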

Compound 4, a percentage reported as inhibition, at one concentration (the size of the read-out at that concentration, not a potency): 19.7%
Beside the measured number, compound 4's estimate is 30.3 percentage points above it, outside the stated range (below it).
By their numbers in this assay, from the lowest: compounds 1 and 4 (each within the scatter of the next); then compound 2; then compound 3.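

In this assay the read-out falls by a number 64.7 percentage points lower from compound 3 to compound 4 (beyond the scatter) as its step, so methyl to benzyl on this amine nitrogen in a ring removes most of the effect. Compound 2 goes against any rule that a larger group here lowers the read-out, with a number 17.9 percentage points lower from compound 2 to compound 4 (beyond the scatter) as the step. A further phenyl on the saturated chain carbon gives no readable difference, with a number 9.8 percentage points higher from compound 1 to compound 4 (within the scatter) as the step.

Going by these compounds, whether ethyl, 2-hydroxyethyl or a free hydrogen on this nitrogen holds the read-out remains open. Nothing on hand explains these steps.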